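From a Chloro-Methylphenyl Amide to a 1,2-Oxazol-3-yl Amide

The source may report more compounds than this note shows. Statements on the series, on what has been measured and on what is new or still open speak of the compounds shown alone.

Compound 1 `O=C(Nc1ccc(Cl)c(-c2nnc3c(Cl)cccn23)c1)c1ccccn1`: 92000 nM
Compound 2 `O=C(Nc1ccc(Cl)c(-c2nnc3c(Cl)cccn23)c1)c1ccc(Cl)cc1`: > 100000 nM
Compound 3 `Cc1cc(Cl)ccc1C(=O)Nc1ccc(Cl)c(-c2nnc3c(Cl)cccn23)c1`: > 100000 nM

In a functional assay on MDA-MB-231 cells (Homo sapiens) for antiproliferative activity, read by MTT assay, with stated times of 72 h and 4 h (on this read-out lower numbers stand for stronger inhibition and higher numbers for weaker inhibition), compound 1 gives 92000 nM. For compound 2 the assay reports only a limit, > 100000 nM. Compound 3 likewise yields only a limit, > 100000 nM. Two of the three values thus sit at the limit of > 100000 nM in this assay, at which 2 of the 3 values shown sit, so compound 3 stands at the weak end and cannot be separated from compound 2 on these numbers.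

Compound 4 `O=C(Nc1ccc(Cl)c(-c2nnc3c(Cl)cccn23)c1)c1ccon1` carries 1,2-oxazol-3-yl in place of 4-chloro-2-methylphenyl on a carbonyl carbon. Going by the values given here, the steps that bear on it are an at least 1.0-fold higher number from compound 1 to compound 3 (0.03 log units; that floor lies within the scatter) and an at least 1.0-fold higher number from compound 1 to compound 2 (0.03 log units; that floor lies within the scatter), both within the scatter, while a step that the two limits leave unreadable from compound 2 to compound 3. Compound 1, bearing a five- or six-membered hetero-aromatic ring on the carbonyl carbon, gives 92000 nM. Compound 4 is therefore expected to sit near 90000 nM, within 30000 nM to 300000 nM. This expectation means an at least 1.1-fold lower number from compound 3 to compound 4 (0.04 log units; that floor lies within the scatter), a step the limit of compound 3 leaves only loosely defined.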

Compound 4, half-maximal inhibitory concentration: > 100000 nM
Compound 4: no number, only a limit; the forecaster's own chance of this, stated with the estimate: 45%; at least 1.1-fold (0.04 log units) between middle value and limit.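

In this assay compound 4 yields only a limit, > 100000 nM. The five-membered 1,2-oxazol-3-yl on the carbonyl carbon thus gives no readable gain over the six-membered pyridin-2-yl, with an at least 1.0-fold higher number from compound 1 to compound 4 (0.03 log units; that floor lies within the scatter). The steps from compound 2 and from compound 3 to compound 4 cannot be read: the limit of > 100000 nM in this assay, at which 3 of the 4 values shown sit.

As far as these compounds go, whether an amine or a carboxylic acid carried on the ring at this carbonyl carbon would give a number clearly under that limit stays open. Also open, from the compounds shown here alone, is whether any change to the shared core would move these values.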